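The source may hold more compounds than are shown below. What is called first, only, known or untested is meant among the compounds shown, and "the series" means these compounds.

Measured so far:
compound 1 `Oc1cccc(-c2cc(-c3ccccc3)cc(-c3ccsc3)n2)c1`: 6.8%
compound 2 `Oc1cccc(-c2cc(-c3ccccc3)cc(-c3ccco3)n2)c1`: 0%
compound 3 `Oc1cccc(-c2cc(-c3ccccc3)nc(-c3ccsc3)c2)c1`: 3.2%

In an assay on isolated protein for inhibition of DNA topoisomerase 1 (Homo sapiens), with a stated time of 30 min, tested at 20 uM (on this read-out lower numbers stand for a weaker effect and higher numbers for a stronger effect at the one concentration tested), compound 1 gives 6.8% and compound 2 gives 0%. The change furan-2-yl in place of thiophen-3-yl on an aromatic carbon produced a number 6.8 percentage points lower from compound 1 to compound 2 (within the scatter). Compound 3 gives 3.2% in this assay; it has the same atoms as compound 1 joined differently, and the difference between the two cores is not broken down here. Compound 4 `Oc1cccc(-c2cc(-c3ccccc3)nc(-c3ccco3)c2)c1` is not yet measured. It is reached from compound 3 by furan-2-yl in place of thiophen-3-yl on an aromatic carbon, the same change as between compound 1 and compound 2, at the same place. The expectation rests on compound 3 standing at 3.2% and on the earlier step of a number 6.8 percentage points lower from compound 1 to compound 2 (within the scatter), which left the read-out within the scatter. Compound 4 is therefore expected to give about 1% in this assay, between 0% and 8%. The expected step is a number 2.2 percentage points lower from compound 3 to compound 4 (within the scatter).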

Compound 4, a percentage reported as inhibition, at one concentration (the size of the read-out at that concentration, not a potency): 3.5%
For compound 4 the middle estimate is 2.5 percentage points below the measured one; the measured number falls inside the stated range.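

In this assay, furan-2-yl in place of thiophen-3-yl on an aromatic carbon of the second core gives a number 0.3 percentage points higher from compound 3 to compound 4 (within the scatter). Set beside the step on the first core, the change reads the same on both cores: the same change on two cores in this assay, a number 6.8 percentage points lower (within the scatter) from compound 1 to compound 2 and a number 0.3 percentage points higher (within the scatter) from compound 3 to compound 4, 7.1 percentage points apart, within the scatter of two such steps. This shows that the change left the read-out within the scatter on both cores, but with all four numbers this small it does not show that a real effect carries from one core to the other.

Open, from the compounds shown here alone, is whether an amine or a carboxylic acid in place of the five-membered ring would move the read-out beyond the scatter. Also open, going by these compounds, is whether the swap between thiophen-3-yl and furan-2-yl would stay silent on a compound with a stronger effect.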